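The source may report more compounds than this note shows. Statements on the series, on what has been measured and on what is new or still open speak of the compounds shown alone.

Compound 1 `COc1ccc(-c2ccc(C(=O)N[C@H](C)CCCc3cccnc3)cc2Br)cc1OC` is the weaker of the two compounds measured in an assay (Canis lupus familiaris) for binding affinity to platelet-activating factor receptor (Homo sapiens), read by radioligand binding (on this read-out higher numbers stand for weaker inhibition and lower numbers for stronger inhibition), where compound 1 gives 180 nM. Compound 2 `COc1cccc(-c2ccc(C(=O)N[C@H](C)CCCc3cccnc3)cc2)c1` gives 20 nM in this assay, a gap that lies beyond the scatter. Compound 3 `C=CCc1cc(C(=O)N[C@H](C)CCCc2cccnc2)ccc1-c1ccc(OC)c(OC)c1` differs from compound 1 by allyl in place of bromo on an aromatic carbon, placed ortho to a 3,4-dimethoxyphenyl group. Among the measured compounds shown here, no measured pair shows this exchange, so the step from compound 1 to compound 3 is expected to be small, near the scatter, with a lean toward a lower number, as a 1.3-fold lower number from compound 1 to compound 3 (0.11 log units; within the scatter). Compound 3 is therefore estimated at 140 nM, within 40 nM to 500 nM.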

Compound 3, half-maximal inhibitory concentration: 80 nM
For compound 3 the middle estimate is 1.8-fold (0.24 log units) above the measured one; the range from low to high includes it.
By their numbers in this assay, from the lowest: compound 2; then compound 3; then compound 1.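

In this assay, replacing bromo with allyl on this aromatic carbon, ortho to a 3,4-dimethoxyphenyl group, gives a 2.3-fold lower number from compound 1 to compound 3 (0.35 log units; beyond the scatter) and so a modest gain. Among the compounds shown here, this is the first single-place change read here, and it shows that this position tolerates a larger group with a double bond outside the aromatic rings. Nothing given here accounts for the step. The compounds shown leave open whether that double bond matters, which a propyl chain would test. They also leave open how an amine or a carboxylic acid would read at this carbon.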